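Amino in Place of Methoxy: One Step Measured, One Expected

The source may hold more compounds than are shown below. What is called first, only, known or untested is meant among the compounds shown, and "the series" means these compounds.

In a functional assay on MCF7 cells (Homo sapiens) for cytotoxicity, read by MTT assay, with a stated time of 3 days (on this read-out higher numbers stand for weaker inhibition and lower numbers for stronger inhibition), three compounds have been measured:
compound 1 `COc1cccc(-c2cccc(O)c2)c1` gives 33 ug/mL;
compound 2 `Nc1cccc(-c2cccc(O)c2)c1` gives 99 ug/mL;
compound 3 `COc1ccc(-c2cccc(O)c2)cc1` gives 48 ug/mL.

From compound 1 to compound 2 the change is amino in place of methoxy on an aromatic carbon, and it produced a 3.0-fold higher number from compound 1 to compound 2 (0.48 log units; beyond the scatter). Compound 3 shares its atoms with compound 1 but joins them differently; the difference between the two cores is not broken down here. Its value lies within the scatter of that of compound 1, so no order between them is claimed, while it sits beyond the scatter from compound 2.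

Compound 4 `Nc1ccc(-c2cccc(O)c2)cc1` is not yet measured. It differs from compound 3 by amino in place of methoxy on an aromatic carbon. This is the same kind of change as that from compound 1 to compound 2, though the place differs: there the amino sits meta to a group of 7 heavy atoms, here para to it. Resting on the single measured step, compound 4 is expected to show a 2.5-fold higher number from compound 3 to compound 4 (0.40 log units; beyond the scatter) in this assay. Compound 4 is therefore estimated at about 120 ug/mL, expected to fall between 60 ug/mL and 250 ug/mL.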

Compound 4, half-maximal inhibitory concentration: > 100 ug/mL
Compound 4: no number, only a limit; the forecaster's own chance of this, stated with the estimate: 15%; the middle value lies beyond the limit too.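

On the second core, amino in place of methoxy gave an at least 2.0-fold higher number from compound 3 to compound 4 (0.31 log units; beyond the scatter) in this assay, so the direction seen on the first core held here as well. Compound 4 gives > 100 ug/mL, which is a limit of the assay and not a number. The change therefore carries over in direction, but its size on the second core is unsettled, and the comparison between the two cores goes no further than this: the same change on two cores in this assay, a 3.0-fold higher number (0.48 log units; beyond the scatter) from compound 1 to compound 2 and an at least 2.0-fold higher number (0.31 log units; beyond the scatter) from compound 3 to compound 4; the limit leaves it open whether they differ

The direction rests on two pairs only, both with methoxy leaving and amino entering on an aromatic carbon, and so says nothing about this change on any other core. The compounds shown also leave open what an ethoxy group, a carboxylic acid or a longer chain would give in the place of the methoxy, and whether the step seen with amino would be shared by any such group.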